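Quinone series: acetoxy to hydroxy on the shared core

This account rests on a few compounds, and the source may have more. Where it says the series, first, only, none or still open, it means among the compounds named here.

Three compounds have numbers in a functional assay on DU-145 cells (Homo sapiens) for cytotoxicity, read by XTT assay, with a stated time of 24 h; on this read-out higher numbers stand for weaker inhibition and lower numbers for stronger inhibition. Compound 1 `CC(=O)Oc1cc(OC(C)=O)c2c(OC(C)=O)cc(C)c(Cl)c2c1OC(C)=O` gives 59600 nM. Compound 2 `Cc1cc(O)c2c(c1F)C(=O)C=CC2=O` gives 15400 nM. Compound 3 `CC(=O)Oc1c(C)cc(Cl)c2c1C(=O)C=CC2=O` gives 12500 nM, the lowest of the three numbers; its gap to compound 2 lies within the scatter, its gap to compound 1 beyond it. Compound 4 `Cc1cc(Cl)c2c(c1O)C(=O)C=CC2=O` has not been measured. It differs from compound 3 by hydrogen in place of acetyl on an oxygen on an aromatic ring, that is acetoxy to hydroxy. Among the compounds with values here, no measured pair shows this change on its own, and compound 2, which also carries a free hydroxy on the core, gives a number within the scatter of compound 3. The step of a 1.1-fold higher number from compound 3 to compound 4 (0.05 log units; within the scatter) is therefore expected to stay within the scatter, in no particular direction. Compound 4 is estimated at 14000 nM, within 5000 nM to 40000 nM.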

Compound 4, half-maximal inhibitory concentration: 9300 nM
Beside the measured number, compound 4's estimate is 1.5-fold (0.18 log units) above it; low and high end bracket the measured number.
By their numbers in this assay, from the lowest: compounds 4, 3 and 2 (each within the scatter of the next); then compound 1.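

In this assay, within the data shown here, the step of a 1.3-fold lower number from compound 3 to compound 4 (0.13 log units; within the scatter) is the first direct reading of acetoxy to hydroxy on this oxygen on an aromatic ring, and it lies within the scatter. On this one pair, the acetyl can be replaced by hydrogen at this position without a difference the assay can separate from repeat measurements. No evidence bearing on the reason for this result is at hand.

Going by these compounds, whether the same holds with other substituents on the shared core remains open. Also open, on these data alone, is how this position reads with a methoxy group or an amine in place of the hydroxy.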